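The source may report more compounds than this note shows. Statements on the series, on what has been measured and on what is new or still open speak of the compounds shown alone.

Measured in a functional assay on L02 cells (Homo sapiens) for inhibition, read by MTT assay, with a stated time of 48 h; on this read-out higher numbers stand for weaker inhibition and lower numbers for stronger inhibition:

Compound 1 `O=C(/C=C/c1coc2cc(O)ccc2c1=O)NCc1ccccc1` gives > 200000 nM, which is a limit of the assay and not a number.
Compound 2 `COc1ccc2c(=O)c(/C=C/C(=O)NCc3cccc(F)c3)coc2c1` gives > 200000 nM, again a limit of the assay.
Compound 3 `COc1ccc(NC(=O)/C=C/c2coc3cc(O)ccc3c2=O)cc1` gives > 200000 nM, again a limit of the assay.

Compound 2 therefore stands at the limit of this assay, and so do the other two measured compounds; (the limit of > 200000 nM in this assay, at which 3 of the 3 values shown sit). For the measured compounds named here, the only step between measured compounds that differ in one place, a step that the two limits leave unreadable from compound 1 to compound 3, cannot be read, since both of its ends are limits. It concerns the amide-type nitrogen and not the benzyl group, so it says nothing about a change of fluorine on that group.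

Compound 4 `COc1ccc2c(=O)c(/C=C/C(=O)NCc3ccc(F)cc3F)coc2c1` differs from compound 2 by 2,4-difluorophenyl in place of 3-fluorophenyl on a saturated chain carbon bound to an amide-type nitrogen. Going by the values given here, no measured step bears on this change: no pair among the measured compounds differs in the fluorine on the benzyl group, and the one measured step is unreadable. The expectation for compound 4 thus rests only on where compound 2 stands, which is at the limit.

For compound 4 the step estimated from compound 2 is a step that the limit leaves unreadable from compound 2 to compound 4, expected as none beyond the scatter. Compound 4 is expected in this assay at about 300000 nM, in a range from 150000 nM to 1000000 nM, and most likely reported again as a limit rather than a number.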

Compound 4, half-maximal inhibitory concentration: > 200000 nM
Compound 4 ended at the assay's limit; the forecaster's own chance of this, stated with the estimate: 85%; the middle value lies beyond the limit too.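

No new step can be read from compound 2 to compound 4: both ends are limits of the assay, not numbers. The compounds shown leave open whether any change on the amide-type nitrogen or on the benzyl group moves the read-out off that limit at all: the limit of > 200000 nM in this assay, at which 4 of the 4 values shown sit.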